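The source may hold more compounds than are shown below. What is called first, only, known or untested is meant among the compounds shown, and "the series" means these compounds.

In a functional assay on SNB-75 cells (Homo sapiens) for inhibition, read by sulforhodamine B assay, with a stated time of 48 h, tested at 10 uM (a higher number here means more inhibition of growth at the concentration tested, a lower number less inhibition of growth), compound 2 (`C/C(=N/O)c1ccc(NC(=O)Cn2nc(C(F)(F)F)nc2N)cc1`) gives 14.8% and compound 1 (`CC(=O)c1ccc(NC(=O)Cn2nc(-c3ccc(Cl)cc3)nc2N)cc1`), which carries acetyl, gives 6.47%. These two values lie within the scatter of each other, and the two compounds differ in more than one place. Compound 3 (`CC(=O)c1ccc(NC(=O)Cn2nc(C(F)(F)F)nc2N)cc1`) differs from compound 2 at one place, on an aromatic carbon, para to a large group: a group of 3 heavy atoms (2 carbon, 1 oxygen; no ring) in place of a group of 4 heavy atoms (2 carbon, 1 nitrogen, 1 oxygen; no ring), on an aromatic carbon. Going by the values given here, no measured pair shows this change, so no step beyond the scatter is expected in this assay, in either direction. The expected change is a number 4.8 percentage points lower from compound 2 to compound 3 (within the scatter). Compound 3 is estimated at 10%, with an expected range of 2% to 22%.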

Compound 3, percent growth inhibition at one concentration: 12.5%
Compound 3: the middle estimate sits 2.5 percentage points below what was measured; low and high end bracket the measured number.
By their numbers in this assay, from the lowest: compounds 1, 3 and 2 (each within the scatter of the next).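

In this assay, acetyl in place of the group of 4 heavy atoms, on an aromatic carbon para to a large group, gives a number 2.3 percentage points lower from compound 2 to compound 3 (within the scatter) and so removes the one hydrogen-bond donor of that group without a readable change. Trifluoromethyl in place of 4-chlorophenyl, at another place on the shared core, gives a number 6 percentage points higher from compound 1 to compound 3 (within the scatter) and is likewise no readable change.

As far as these compounds go, whether an amine or a carboxylic acid on that aromatic carbon would give a step beyond the scatter stays open. No measurement at hand offers a reason for either step.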